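The source may hold more compounds than are shown below. What is called first, only, known or untested is meant among the compounds shown, and "the series" means these compounds.

Working notes on the series. Compound 1 `CC[C@H](C)[C@H](NC(=O)[C@@H](C[C@H](O)[C@H](CC1CCCCC1)NC(=O)[C@H](CO)NC(=O)COc1cccc2ccccc12)C(C)C)C(=O)N(C)c1ccccn1` gives 0.553 h in an ADME assay for pharmacokinetics; a lower number here means that the compound disappears faster, a higher number that the compound lasts longer. Compound 2 `CC[C@H](C)[C@H](NC(=O)[C@@H](C[C@H](O)[C@H](CC1CCCCC1)NC(=O)[C@@H](NC(=O)COc1cccc2ccccc12)C(C)OP(=O)(O)O)C(C)C)C(=O)N(C)c1ccccn1` gives 0.47 h in this assay; the values of compound 1 and compound 2 lie within the scatter of each other, as the step of a 1.2-fold lower number from compound 1 to compound 2 (0.07 log units; within the scatter) shows. Compound 3 `CC[C@H](C)[C@H](NC(=O)[C@@H](C[C@H](O)[C@H](CC1CCCCC1)NC(=O)[C@H](COP(=O)(O)O)NC(=O)COc1cccc2ccccc12)C(C)C)C(=O)N(C)c1ccccn1` is not yet measured. It differs from compound 2 by hydrogen in place of methyl on a saturated chain carbon bound to an oxygen on an unsaturated carbon and a saturated chain carbon, a change at the same part of the shared core that was altered between compound 1 and compound 2. Among the compounds with values here, the only step bearing on this position, a 1.2-fold lower number from compound 1 to compound 2 (0.07 log units; within the scatter), was a larger structural change than the loss of a methyl and still stayed within the scatter, so no step beyond the scatter is expected for a 1.1-fold higher number from compound 2 to compound 3 (0.03 log units; within the scatter) in this assay. Compound 3 is therefore expected to give about 0.5 h in this assay, with a range of 0.28 h to 0.9 h.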

Compound 3, half-life: 0.838 h
For compound 3 the middle estimate is 1.7-fold (0.22 log units) below the measured one; low and high end bracket the measured number.
By their numbers in this assay, from the lowest: compounds 2, 1 and 3 (each within the scatter of the next).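

The step from compound 1 to compound 2 carried two changes at once, and compound 3 lets them be read apart in this assay. Hydrogen in place of methyl on the saturated chain carbon alone gives one step (a 1.8-fold higher number from compound 2 to compound 3 (0.25 log units; within the scatter)), and the group in place of a hydrogen atom on the oxygen on a saturated carbon alone gives the other (a 1.5-fold higher number from compound 1 to compound 3 (0.18 log units; within the scatter)), so at this part of the shared core neither change on its own leaves the scatter. The data in hand give no reason for these numbers. On these data alone, whether a carboxylic acid or an amine in place of the group on that oxygen would also stay within the scatter in this assay remains open. So does the outcome for a longer chain in place of the methyl.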